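Piperidin-1-yl in place of pyrrolidin-1-yl in compound 2

The source may hold more compounds than are shown below. What is called first, only, known or untested is meant among the compounds shown, and "the series" means these compounds.

Compound 1 `Clc1ccc(C2CC3(N4CCCCC4)CCNC2C(c2ccc(Cl)c(Cl)c2)C3)cc1Cl`: 8870 nM
Compound 2 `NCCN1CCC2(N3CCCC3)CC(c3ccc(Cl)cc3)C1C(c1ccc(Cl)cc1)C2`: 4650 nM
Compound 3 `CN(C)C12CCNC(C(c3cccc4ccccc34)C1)C(c1cccc3ccccc13)C2`: 6470 nM

In an ADME assay on L6 cells (Rattus norvegicus) for cytotoxicity, read by resazurin assay, with a stated time of 72 h (on this read-out higher numbers stand for weaker inhibition and lower numbers for stronger inhibition), compound 2 gives 4650 nM as its value. Compound 1 at 8870 nM and compound 3 at 6470 nM both lie within the usual scatter of that number, so the three measured compounds cannot be ranked on this evidence.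

Compound 4 `NCCN1CCC2(N3CCCCC3)CC(c3ccc(Cl)cc3)C1C(c1ccc(Cl)cc1)C2` has not yet been measured in this assay and differs from compound 2 in one place: piperidin-1-yl in place of pyrrolidin-1-yl on a saturated ring carbon. In words, piperidin-1-yl stands in place of pyrrolidin-1-yl on a saturated ring carbon.

Within the data shown here, no measured pair isolates this change, so the data offer no direct size for it. Compound 1 at 8870 nM also carries piperidin-1-yl, but it differs from compound 2 elsewhere too, and the two values stay within the scatter of each other. On that slim basis, no step beyond the scatter is expected in either direction. The estimated step is a 1.2-fold higher number from compound 2 to compound 4 (0.07 log units; within the scatter) and it is expected to stay within the scatter. For compound 4 the estimated value is 5500 nM (expected range from 2700 nM to 11000 nM).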

Compound 4, half-maximal inhibitory concentration: 3370 nM
Compound 4: middle estimate off by 1.6-fold (0.21 log units), on the high side, within the range that was stated.
By their numbers in this assay, from the lowest: compounds 4, 2, 3 and 1 (each within the scatter of the next, the first and the last beyond it).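

In this assay, the exchange of pyrrolidin-1-yl for piperidin-1-yl on a saturated ring carbon can now be read on its own, as a 1.4-fold lower number from compound 2 to compound 4 (0.14 log units; within the scatter). Among these compounds, compound 1 also carries piperidin-1-yl but differs from compound 2 elsewhere too, so only this pair, on an otherwise unchanged structure, shows that going from the five-membered to the six-membered ring at this position produces no step beyond the scatter, and compound 2 and compound 4 cannot be ranked. Nothing available bears on why the two compounds read alike in this cell assay.

Going by these compounds, it remains open whether morpholin-4-yl or azepan-1-yl on the same carbon, or an open-chain amine such as diethylamino, would stay within the scatter of compound 2 as well. On these data alone, it is also open whether the exchange of pyrrolidin-1-yl for piperidin-1-yl would give a similarly small step on the core of compound 1, so the result cannot yet be extended beyond this single pair.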